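A few compounds are considered here, and "the series" means these few. Any claim that something is new, unique, unknown or untested is made for them only; others in the source may bear on it.

Measured in a physicochemical assay for solubility, in phosphate buffer, with a stated time of 18 h, at pH 7; a higher number here means a more soluble compound, a lower number a less soluble compound:
- compound 1 `CC(C)CN1C(=O)c2ccccc2[C@H](C(=O)Nc2ccc(F)c(C#N)c2)[C@H]1C1CCCNC1` gives 54000 nM
- compound 2 `CC(C)CN1C(=O)c2ccccc2[C@H](C(=O)Nc2ccc(F)c(C#N)c2)[C@H]1c1ccc(C(N)=O)s1` gives 19000 nM
- compound 3 `CC(C)CN1C(=O)c2ccccc2[C@H](C(=O)Nc2ccc(F)c(C#N)c2)[C@H]1c1ccnnc1` gives 28000 nM

Compound 3 lies within the scatter of both other compounds, with a 1.9-fold lower number from compound 1 to compound 3 (0.29 log units; within the scatter) and a 1.5-fold higher number from compound 2 to compound 3 (0.17 log units; within the scatter). Only a 2.8-fold lower number from compound 1 to compound 2 (0.45 log units; beyond the scatter) goes beyond the scatter, and that step is modest.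

The next analogue is compound 4 `CC(C)CN1C(=O)c2ccccc2[C@H](C(=O)Nc2ccc(F)c(C#N)c2)[C@H]1c1csnn1`. It differs from compound 3 in one group on the saturated ring carbon next to the ring nitrogen: 1,2,3-thiadiazol-4-yl in place of pyridazin-4-yl on a saturated ring carbon. This puts 1,2,3-thiadiazol-4-yl in place of pyridazin-4-yl.

Among the compounds with values here, no measured step covers this exchange directly. The closest is a 1.5-fold higher number from compound 2 to compound 3 (0.17 log units; within the scatter), an exchange between two aromatic groups on the same carbon, and it stays within the scatter. Across these three compounds, changing the group on this carbon has given a modest step at the largest. One measured analogue also carries a five-membered aromatic ring: compound 2 gives 19000 nM, so the expectation leans slightly downward.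

In this assay, no change beyond the scatter is expected, and the estimated step is a 1.3-fold lower number from compound 3 to compound 4 (0.10 log units; within the scatter). The estimate for compound 4 is 22000 nM, with an expected range of 9000 nM to 50000 nM.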

Compound 4, solubility: 5000 nM
Compound 4: middle estimate off by 4.4-fold (0.64 log units), on the high side, and the stated range ends above it.
By their numbers in this assay, from the lowest: compound 4; then compounds 2, 3 and 1 (each within the scatter of the next, the first and the last beyond it).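

In this assay, within the data shown here, the group on the saturated ring carbon next to the ring nitrogen now gives the first large step, an 11-fold lower number from compound 1 to compound 4 (1.03 log units; beyond the scatter), and 1,2,3-thiadiazol-4-yl sits beyond the scatter of all three other groups. Two aromatic groups on this carbon, previously within the scatter of each other, are now shown to be clearly separable, with a 5.6-fold lower number from compound 3 to compound 4 (0.75 log units; beyond the scatter), and a five-membered aromatic ring does not by itself fix the number, as seen in a 3.8-fold lower number from compound 2 to compound 4 (0.58 log units; beyond the scatter). No measurement here bears on the origin of these differences.

Still open, as far as these compounds go, is whether the low number of compound 4 goes with the ring size, the sulfur or the arrangement of hetero atoms, given that compound 2 also carries a five-membered aromatic ring with sulfur, together with a carbamoyl group. Unsubstituted thiophen-2-yl and 1,2,3-triazol-4-yl on this carbon would help to separate these features, as each differs from 1,2,3-thiadiazol-4-yl in its ring atoms.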